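The compounds below may be only part of what the source reports. "The series", "measured", "known", "first", "only" and "open" are said of these compounds alone.

Compound 1 `O=C1/C(=C/c2ccccc2F)CN(Cc2cn(Cc3ccccc3F)nn2)C/C1=C\c1ccccc1F`: 41200 nM
Compound 2 `COc1ccc(/C=C2\CN(Cc3cn(Cc4cccc(Cl)c4)nn3)C/C(=C\c3ccc(OC)cc3)C2=O)cc1`: > 100000 nM (a limit of the assay)
Compound 3 `Cc1ccc(/C=C2\CN(Cc3cn(Cc4ccc(F)cc4)nn3)C/C(=C\c3ccc(C)cc3)C2=O)cc1`: "not determined" (no result reported)

Among the compounds with values here, in an ADME assay on HEK293 cells (Homo sapiens) for cytotoxicity, read by MTT assay, with a stated time of 24 h (on this read-out higher numbers stand for weaker inhibition and lower numbers for stronger inhibition), compound 1 gives 41200 nM, the only actual number in this small set. Compound 2 reaches only a limit of the assay, > 100000 nM. Compound 3 has no result, so neither neighbour offers a measured comparison.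

Compound 4 `O=C1/C(=C/c2ccccc2F)CN(Cc2cn(Cc3ccccc3Cl)nn2)C/C1=C\c1ccccc1F` departs from compound 1 by chloro in place of fluoro on an aromatic carbon, turning 2-fluorobenzyl into 2-chlorobenzyl. Within the data shown here, no measured pair shows what such a swap does, so no change beyond the usual scatter is expected, and the estimate rests on compound 1 at 41200 nM. The expected change is a 1.2-fold lower number from compound 1 to compound 4 (0.07 log units; within the scatter). For compound 4 the estimated value is 35000 nM, within an expected range of 15000 nM to 80000 nM.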

Compound 4, half-maximal inhibitory concentration: 33200 nM
Compound 4: middle estimate off by 1.1-fold (0.02 log units), on the high side; the measured number falls inside the stated range.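

Within the data shown here, compound 1 and compound 4 form the first measured pair in this set that differs in one place, and swapping fluoro for chloro on the benzyl ring gives, in this assay, a 1.2-fold lower number from compound 1 to compound 4 (0.09 log units; within the scatter). At this place, on this read-out, the two halogens are therefore not told apart. Nothing on hand bears on why this is so.

The compounds shown leave open whether an amine or a carboxylic acid at this place would move the number beyond the scatter. They also leave open whether the same swap on the two 2-fluorophenyl groups would behave alike.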